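This account rests on a few compounds, and the source may have more. Where it says the series, first, only, none or still open, it means among the compounds named here.

Series overview, measured in an ADME assay on isolated protein for inhibition of Amine oxidase [flavin-containing] B (Homo sapiens); on this read-out lower numbers stand for stronger inhibition and higher numbers for weaker inhibition:
compound 1 `C#CCNC1CCc2c(SCc3cccc(OC)c3)cccc21` gives 1520 nM
compound 2 `C#CCNC1CCc2c(SCc3ccccc3)cccc21` gives "not active" (no number reported)
compound 3 `C#CCNC1CCc2c(SCc3cccc(C(F)(F)F)c3)cccc21` gives 7710 nM

Compound 2 stands at the bottom of the set with no number at all. Compound 4 `C#CCNC1CCc2c(SCc3ccc(C)cc3)cccc21` differs from it by methyl in place of hydrogen on an aromatic carbon. Among the measured compounds shown here, the one measured step, a 5.1-fold higher number from compound 1 to compound 3 (0.71 log units; beyond the scatter), concerns an exchange at a different place on the same ring, so it does not bear directly on this change; it only shows that a substituent on this ring can move the read-out in this assay by a modest amount. Any group on the ring so far gives a number where compound 2 gives none, so compound 4 is expected to register weakly, with a real chance of no number again. Compound 4 is estimated at 12000 nM, range 2500 nM to 60000 nM.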

Compound 4, half-maximal inhibitory concentration: 320 nM
Compound 4: the middle estimate sits 38-fold (1.57 log units) above what was measured; measured number outside the range, below it.
By their numbers in this assay, from the lowest: compound 4; then compound 1; then compound 3.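

In this assay, among the compounds shown here, compound 2 has no number, so no step to compound 4 can be read. No supporting data bear on this result. The compounds shown leave open how large the change from phenyl to 4-methylphenyl is.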